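Swapping 4-methylpiperazin-1-yl for piperidin-1-yl on compound 3

A few compounds are considered here, and "the series" means these few. Any claim that something is new, unique, unknown or untested is made for them only; others in the source may bear on it.

Of the compounds shown here, three sharing one core have been measured in a functional assay on MCF7 cells (Homo sapiens) for inhibition, read by CCK-8 assay, with a stated time of 48 h; on this read-out lower numbers stand for stronger inhibition of growth and higher numbers for weaker inhibition of growth. Compound 1 (`Cc1ccccc1Nc1nc(NCc2ccco2)ncc1Cl`) gives > 100000 nM, which is a limit of the assay and not a number. Compound 2 (`Cc1ccccc1Nc1nc(Nc2cc(Cl)ccn2)ncc1Cl`) gives > 100000 nM, again a limit. Within the data shown here, compound 3 (`Cc1ccccc1Nc1nc(Nc2ccc(N3CCN(C)CC3)cn2)ncc1Cl`) gives 5210 nM, the only true number of the three.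

The next compound, compound 4 (`Cc1ccccc1Nc1nc(Nc2ccc(N3CCCCC3)cn2)ncc1Cl`), keeps everything in compound 3 except one group: piperidin-1-yl in place of 4-methylpiperazin-1-yl on an aromatic carbon.

Among the measured compounds shown here, the one measured step, a step that the two limits leave unreadable from compound 1 to compound 2, has no readable size and concerns a different group, so it does not bear on this exchange. For the measured compounds named here, no measured step covers the change itself. Going by the values given here, the only guide is that compound 3, at 5210 nM, is the sole compound here carrying 4-methylpiperazin-1-yl and the sole one to give a number, although compounds 1 and 2 differ from it by more than that group. A modest move toward weaker inhibition of growth in this assay is therefore expected, held with little confidence. The estimated step is a 2.1-fold higher number from compound 3 to compound 4 (0.32 log units; beyond the scatter). For compound 4 the expected value is 11000 nM, with an estimated range of 3000 nM to 50000 nM.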

Compound 4, concentration for 50% growth inhibition: 21400 nM
Beside the measured number, compound 4's estimate is 1.9-fold (0.29 log units) below it; the measured number falls inside the stated range.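

In this assay, among these compounds, the exchange gives the first readable step at this position, on an aromatic carbon two atoms from the ring nitrogen, and it is a 4.1-fold higher number from compound 3 to compound 4 (0.61 log units; beyond the scatter). The entering piperidin-1-yl has 1 hetero atom and 1 hydrogen-bond acceptor where 4-methylpiperazin-1-yl has 2 of each, and with that change compound 4 still gives a true number, 21400 nM, so a measurable value at this position does not depend on 4-methylpiperazin-1-yl alone. The step from compound 1 to compound 2 cannot be read, which leaves this single exchange as the only sized comparison in the set: the limit of > 100000 nM in this assay, at which 2 of the 4 values shown sit.

The compounds shown do not separate the contribution of the second ring nitrogen from that of its methyl, a question that an unsubstituted piperazin-1-yl or a morpholin-4-yl at the same place would bear on. They also leave open whether an open-chain amine such as dimethylamino, or a carboxylic acid carried on the ring, would move the value in the same direction as this exchange or in the opposite one.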